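This account rests on a few compounds, and the source may have more. Where it says the series, first, only, none or still open, it means among the compounds named here.

Compound 1 `COc1ccc(-n2c(SCC(=O)c3ccc4ccccc4c3)nnc2-c2cc(OC)c(OC)c(OC)c2)cc1`: 53400 nM
Compound 2 `COc1cc(-c2nnc(SCc3ccc(F)cc3)n2-c2ccc(N(C)C)cc2)cc(OC)c1OC`: 44300 nM

In a functional assay on HT-29 cells (Homo sapiens) for inhibition, read by MTT assay, with a stated time of 48 h (a lower number here means a stronger inhibitor, a higher number a weaker inhibitor), compound 2 stands within the usual scatter of compound 1, so neither can be called the stronger inhibitor. Compound 3 `COc1cc(-c2nnc(SCC(=O)c3ccc4ccccc4c3)n2-c2ccc(N(C)C)cc2)cc(OC)c1OC` keeps the rest of compound 2 and changes in one place: (naphthalen-2-yl)carbonyl in place of 4-fluorophenyl on a saturated chain carbon bound to a sulfur. Among the measured compounds shown here, no measured pair isolates this change. Compound 1 also carries the (naphthalen-2-yl)carbonyl group and gives 53400 nM, so no step beyond the scatter is expected in this assay, though the uncertainty is wide. The expected size is a 1.1-fold lower number from compound 2 to compound 3 (0.04 log units; within the scatter). For compound 3 the estimated value is 40000 nM, with an expected range of 12000 nM to 100000 nM.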

Compound 3, half-maximal inhibitory concentration: > 60000 nM
Compound 3: a limit, no number; the forecaster's own chance of this, stated with the estimate: 15%; at least 1.5-fold (0.17 log units) between middle value and limit.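

In this assay compound 3 gives a limit, not a number: the limit of > 60000 nM in this assay, at which 1 of the 3 values shown sits.

The earlier compounds shown here offered no pair differing in one place, and there are now two. Replacing 4-fluorophenyl with (naphthalen-2-yl)carbonyl on a saturated chain carbon bound to a sulfur gives an at least 1.3-fold higher number from compound 2 to compound 3 (0.13 log units; that floor lies within the scatter), while dimethylamino in place of methoxy on an aromatic carbon gives an at least 1.1-fold higher number from compound 1 to compound 3 (0.05 log units; that floor lies within the scatter).

Neither change therefore has a measured size, and neither can yet be said to weaken inhibition. Also open, going by these compounds, is what an amine at that chain carbon would give in this assay.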